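A hydroxy group on a core without a measured number

A few compounds are considered here, and "the series" means these few. Any claim that something is new, unique, unknown or untested is made for them only; others in the source may bear on it.

In a functional assay on HT-29 cells (Homo sapiens) for cytotoxicity, read by sulforhodamine B assay, with a stated time of 72 h (on this read-out lower numbers stand for stronger inhibition of growth and higher numbers for weaker inhibition of growth), compound 1 `C=C1CC[C@@H]2[C@](C)(CCC[C@]2(C)C(=O)OC)[C@H]1CCc1ccc2c(OC)ccc(OC)c2c1` gives > 6700 nM, which is a limit and not a number. Compound 2 `C=C1CC[C@@H]2[C@](C)(CCC[C@]2(C)C(=O)OC)[C@H]1CCc1ccc2c(OCc3ccccc3)ccc(OCc3ccccc3)c2c1` carries benzyloxy groups where compound 1 has methoxy groups. Compound 2 gives > 5000 nM, also a limit. Compound 3 `C=C1[C@H](O)C[C@@H]2[C@](C)(CCC[C@]2(C)C(=O)OC)[C@H]1CCc1ccc2c(OC)ccc(OC)c2c1` gives > 6400 nM, again a limit. Compound 1 therefore stands with no measured number, and neither do the other two compounds.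

Compound 4 `C=C1CC[C@@H]2[C@](C)(CCC[C@]2(C)C(=O)OC)[C@]1(O)CCc1ccc2c(OC)ccc(OC)c2c1` differs from compound 1 by hydroxy in place of hydrogen on a saturated ring carbon, a hydroxy in place of hydrogen on a saturated ring carbon. Going by the values given here, the one measured step of the same kind, at another saturated ring carbon, is a step that the two limits leave unreadable from compound 1 to compound 3. It offers no size to carry over, but it gives no sign of a gain either. On that basis, no change beyond the usual scatter is expected in this assay, and another limit is the likeliest report. The expected step is a step that the limit leaves unreadable from compound 1 to compound 4. Compound 4 is estimated at 7000 nM, with an expected range from 3000 nM to 15000 nM.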

Compound 4, concentration for 50% growth inhibition: > 21500 nM
Compound 4: a limit, no number; the forecaster's own chance of this, stated with the estimate: 75%; middle value at least 3.0-fold (0.48 log units) away from the limit.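

In this assay compound 4 gives > 21500 nM, a limit and not a number. Compound 1 also stands at a limit, so no step can be read between compound 1 and compound 4. The compounds shown leave open what hydroxy in place of hydrogen does to growth inhibition.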